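The compounds below may be only part of what the source reports. "The series", "measured", "known", "first", "only" and "open" are said of these compounds alone.

Measured in a functional assay on A549 cells (Homo sapiens), read by MTT assay, with a stated time of 72 h; a higher number here means a weaker inhibitor, a lower number a stronger inhibitor:
- compound 1 `CSc1ncnc2c1c(-c1ccoc1)cn2[C@@H]1O[C@H](CO)[C@@H](O)[C@H]1O`: 280 nM
- compound 2 `C#Cc1cn([C@@H]2O[C@H](CO)[C@@H](O)[C@H]2O)c2ncnc(SC)c12`: 140 nM

Within the data shown here, with only these two numbers, compound 1 has no clear rank, as the single measured step is a 2.0-fold lower number from compound 1 to compound 2 (0.30 log units; within the scatter). Compound 3 `CNc1ncnc2c1c(-c1ccoc1)cn2[C@@H]1O[C@H](CO)[C@@H](O)[C@H]1O` has not yet been measured. It keeps the furan-3-yl group of compound 1 and differs in one other place, with methylamino in place of methylsulfanyl on an aromatic carbon.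

The measured step bears on this change only indirectly. Among the measured compounds shown here, it replaces furan-3-yl with ethynyl and leaves the methylsulfanyl group untouched, so no measured pair tests the new swap. The data therefore give no direction, and no shift beyond the scatter is expected in this assay. The best starting point is simply the value of compound 1, 280 nM, with a wide margin for an untested change.

The expected change is small, a 1.1-fold higher number from compound 1 to compound 3 (0.03 log units; within the scatter). For compound 3 the estimated value is 300 nM, with an expected range of 90 nM to 1000 nM.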

Compound 3, half-maximal inhibitory concentration: > 20000 nM
Compound 3 was reported as a limit; the forecaster's own chance of this, stated with the estimate: 5%; middle value at least 66-fold (1.82 log units) away from the limit.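

Before this result, the only measured step changed the furan-3-yl group, so nothing showed how much the methylsulfanyl position matters in this assay. This position turns out to be highly sensitive, since exchanging methylsulfanyl for methylamino gives an at least 71-fold higher number from compound 1 to compound 3 (1.85 log units; beyond the scatter), even though the two groups match in heavy-atom count and differ in a sulfur replaced by a nitrogen and in the hydrogen-bond donor that methylamino carries. The value for compound 3 is a limit and not a number, so this step marks only the smallest size the change can have: the limit of > 20000 nM in this assay, at which 1 of the 3 values shown sits.

The compounds shown cannot separate the loss of the sulfur from the gain of the donor, and a methoxy group or an unsubstituted amine at this position would bear directly on that question. Among these compounds, it also remains open whether methylamino has the same effect when ethynyl replaces furan-3-yl, as only one pair tests this swap.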